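Tert-Butyl for Trifluoromethylcyclopropyl on a Pyrrolidine Series

The source may report more compounds than this note shows. Statements on the series, on what has been measured and on what is new or still open speak of the compounds shown alone.

Measured so far:
compound 1 `Cn1nc(CN2CCN(c3ccccc3)CC2)nc1-c1ccc(C(C)(C)C)cc1` 0.388 h
compound 2 `Cn1nc(CN2CCCC2)nc1-c1ccc(Cl)c(Cl)c1` 0.085 h
compound 3 `Cn1nc(CN2CCCC2)nc1-c1ccc(C2(C(F)(F)F)CC2)cc1` 0.055 h

In an ADME assay on microsomes from liver (Rattus norvegicus) for metabolic stability, read by LC-MS, using NADPH, with a stated time of 1 h, tested at 10 uM (on this read-out lower numbers stand for a shorter-lived compound and higher numbers for a longer-lived compound), compound 3 gives the lowest of the three half-lives. Its nearest neighbour is compound 2, whose number lies within the scatter of it, while compound 1 stands furthest away, beyond the scatter, with the longest half-life of the three.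

Compound 4 `Cn1nc(CN2CCCC2)nc1-c1ccc(C(C)(C)C)cc1` has not yet been measured in this assay. It differs from compound 3 in one place: tert-butyl in place of 1-(trifluoromethyl)cyclopropyl on an aromatic carbon. Compound 4 shares the pyrrolidine-bearing core of compounds 2 and 3, both of which sit at the short end of the range.

Going by the values given here, no measured pair shows this exact change. The step of a 1.1-fold higher number from compound 3 to compound 4 (0.04 log units; within the scatter) is expected to stay within the scatter, with no clear direction. Compound 4 is therefore estimated at 0.06 h, in a range from 0.025 h to 0.15 h.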

Compound 4, half-life: 0.16 h
Beside the measured number, compound 4's estimate is 2.7-fold (0.43 log units) below it; measured number above the stated range.
By their numbers in this assay, from the lowest: compounds 3, 2 and 4 (each within the scatter of the next, the first and the last beyond it); then compound 1.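

In this assay, replacing 1-(trifluoromethyl)cyclopropyl with tert-butyl on an aromatic carbon, para to a large group, gives a 2.9-fold higher number from compound 3 to compound 4 (0.46 log units; beyond the scatter). Going by these compounds alone, this is the first comparison that changes one place only, and it shows that the group at this position can move the half-life by more than the usual scatter, with tert-butyl giving the longer-lived compound. No measurement here bears on why the half-life moves with this change.

On these data alone, how a nitrile or a methoxy group would behave at this position remains open. So does whether the same change would give a similar step on the core of compound 1.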